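The source may report more compounds than this note shows. Statements on the series, on what has been measured and on what is new or still open speak of the compounds shown alone.

In a functional assay on K562 cells (Homo sapiens) for cytotoxicity, read by trypan blue exclusion, with a stated time of 96 h (a higher number here means a weaker inhibitor, a lower number a stronger inhibitor), compound 3 (`COc1cc(OC)c(/C=C/S(=O)(=O)Cc2ccc(OC)c(NC(F)(F)C(=O)O)c2)c(OC)c1`) gives 150 nM and compound 1 (`COC(=O)C(F)(F)Nc1cc(CS(=O)(=O)/C=C/c2c(OC)cc(OC)cc2OC)ccc1OC`) gives 250 nM, a gap within the scatter (a 1.7-fold lower number from compound 1 to compound 3 (0.22 log units; within the scatter)). Compound 2 (`COC(=O)C(Nc1cc(CS(=O)(=O)/C=C/c2c(OC)cc(OC)cc2OC)ccc1OC)c1ccc(F)cc1`) gives 800 nM and stands clearly apart (a 5.3-fold lower number from compound 2 to compound 3 (0.73 log units; beyond the scatter)). Compound 4 (`COc1cc(OC)c(/C=C/S(=O)(=O)Cc2ccc(OC)c(NC(C(=O)O)c3ccc(F)cc3)c2)c(OC)c1`) carries carboxy(4-fluorophenyl)methyl in place of carboxy(difluoro)methyl on a nitrogen on an aromatic ring. Within the data shown here, the one close precedent is the matching exchange with the methoxycarbonyl group in place of the carboxy group (a 3.2-fold higher number from compound 1 to compound 2 (0.51 log units; beyond the scatter)), a modest step to a higher number. The gap between compound 1 and compound 3 adds no shift beyond the scatter, so a similar modest rise is expected in this assay (a 3.0-fold higher number from compound 3 to compound 4 (0.48 log units; beyond the scatter)). For compound 4 the estimated value is 450 nM (range 170 nM to 1200 nM).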

Compound 4, half-maximal inhibitory concentration: 80 nM
Estimate against measurement, compound 4: 5.6-fold (0.75 log units) above; measured number below the stated range.
By their numbers in this assay, from the lowest: compounds 4, 3 and 1 (each within the scatter of the next, the first and the last beyond it); then compound 2.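

In this assay, carboxy(4-fluorophenyl)methyl in place of carboxy(difluoro)methyl on the nitrogen stays within the scatter (a 1.9-fold lower number from compound 3 to compound 4 (0.27 log units; within the scatter)), so the rise seen for the matching ester pair (a 3.2-fold higher number from compound 1 to compound 2 (0.51 log units; beyond the scatter)) does not carry over to the free acids. Against the ester with the difluoro group, the new acid also lies beyond the scatter (a 3.1-fold lower number from compound 1 to compound 4 (0.49 log units; beyond the scatter)). Hydrogen in place of methyl on the ester oxygen gives a step of a different size on each core, with a 10-fold lower number from compound 2 to compound 4 (1.00 log units; beyond the scatter) the larger: the same change on two cores in this assay, a 1.7-fold lower number (0.22 log units; within the scatter) from compound 1 to compound 3 and a 10-fold lower number (1.00 log units; beyond the scatter) from compound 2 to compound 4, 6.0-fold (0.78 log units) apart, beyond the scatter of two such steps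

Open, on these data alone, is whether a plain phenyl or a 4-chlorophenyl in place of the 4-fluorophenyl would hold the number of compound 4. Also open, as far as these compounds go, is how a primary amide in place of the carboxy group would read.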